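Amide substituent exchange on the shared core

A few compounds are considered here, and "the series" means these few. Any claim that something is new, unique, unknown or untested is made for them only; others in the source may bear on it.

In a functional assay on HeLa cells (Homo sapiens) for inhibition, read by MTT assay, with a stated time of 24 h (a higher number here means a weaker inhibitor, a lower number a stronger inhibitor), compound 1 `CCOC(=O)C1=Cc2ccccc2OC1(OCc1cc(-c2ccc(F)cc2F)no1)C(F)(F)F` reaches only the limit > 150000 nM. Compound 2 `CCOC(=O)C1=Cc2ccccc2OC1(OCc1cn(CC(=O)Nc2cccc(Cl)c2)nn1)C(F)(F)F` gives 12300 nM. Compound 3 `CCOC(=O)C1=Cc2ccccc2OC1(OCc1cn(CC(=O)NC2CCCCC2)nn1)C(F)(F)F` gives 11400 nM, the smaller of the two numbers, yet separated from compound 2 only by a 1.1-fold lower number from compound 2 to compound 3 (0.03 log units; within the scatter), which sits within the scatter. Compound 4 `CCOC(=O)C1=Cc2ccccc2OC1(OCc1cn(CC(=O)Nc2ccc(OC)cc2)nn1)C(F)(F)F` differs from compound 3 by 4-methoxyphenyl in place of cyclohexyl on an amide-type nitrogen. Among the compounds with values here, the one measured step that bears on this change is the exchange of an aromatic ring for cyclohexyl on the same amide-type nitrogen, which barely moved the number; the change from compound 3 to compound 4 runs that exchange back toward an aromatic ring, so no step beyond the scatter is expected, a 1.1-fold higher number from compound 3 to compound 4 (0.02 log units; within the scatter). Compound 4 is therefore estimated at 12000 nM, between 5000 nM and 30000 nM.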

Compound 4, half-maximal inhibitory concentration: 31900 nM
Compound 4: middle estimate off by 2.7-fold (0.42 log units), on the low side, outside the stated range (above it).
By their numbers in this assay, from the lowest: compounds 3 and 2 (each within the scatter of the next); then compound 4. At a limit, above all of these: compound 1.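

At this amide-type nitrogen the substituent does register: the data show a 2.8-fold higher number from compound 3 to compound 4 (0.45 log units; beyond the scatter) and a 2.6-fold higher number from compound 2 to compound 4 (0.41 log units; beyond the scatter) as modest steps, whereas compound 2 and compound 3 stand within the scatter of each other. Carrying an aromatic ring does not settle the number, as 3-chlorophenyl and 4-methoxyphenyl are both aromatic yet their values differ beyond the scatter. Nothing reported here accounts for these steps. From the compounds shown here alone, what a plain phenyl or a 4-hydroxyphenyl on this nitrogen would give remains open, as does whether the ring or its methoxy group carries the step.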